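The source may hold more compounds than are shown below. What is called first, only, known or untested is meant among the compounds shown, and "the series" means these compounds.

Working notes on the series.

Two compounds have numbers in an assay on cells for agonist activity at vitamin D3 receptor (Homo sapiens), read by microscopy; on this read-out lower numbers stand for an effect already at smaller amounts and higher numbers for an effect only at larger amounts of compound. Compound 1 `CCn1c(C(=O)NCCCO)ccc1C(CC)(CC)c1ccc(C#CC(O)(CC)CC)c(C)c1` gives 137 nM in this assay. Compound 2 `CCn1cc(C(CC)(CC)c2ccc(C#CC(O)(CC)CC)c(C)c2)cc1C(=O)NCC(=O)OC` gives 288 nM in this assay, the higher of the two numbers; the gap between compound 1 and compound 2 lies beyond the usual scatter, so compound 2 needs the larger amount of the two.

Compound 3 `CCn1cc(C(CC)(CC)c2ccc(C#CC(O)(CC)CC)c(C)c2)cc1C(=O)NCCCN(C)C` is the next compound, not yet measured in this assay. The change from compound 2 to compound 3 is 2-(dimethylamino)ethyl in place of methoxycarbonyl on a saturated chain carbon bound to an amide-type nitrogen. Within the data shown here, no measured pair isolates this change, so its effect on this assay is not known from the data. Among the measured compounds shown here, the only guide is that compound 1, which carries a different group on the amide nitrogen, gives 137 nM, a number lower than that of compound 2; the amide substituent therefore does move the read-out, but the direction for the present change is open.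

The expected step from compound 2 to compound 3 is a 1.4-fold lower number from compound 2 to compound 3 (0.16 log units; within the scatter), a small shift that may not exceed the scatter. For compound 3 the estimate in this assay is 200 nM, with a range from 70 nM to 600 nM.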

Compound 3, half-maximal effective concentration: 142 nM
Compound 3: middle estimate off by 1.4-fold (0.15 log units), on the high side; the range from low to high includes it.
By their numbers in this assay, from the lowest: compounds 1 and 3 (each within the scatter of the next); then compound 2.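

In this assay, among these compounds, the exchange of methoxycarbonyl for 2-(dimethylamino)ethyl on a saturated chain carbon bound to an amide-type nitrogen gives a 2.0-fold lower number from compound 2 to compound 3 (0.31 log units; beyond the scatter) and is the only measured pair that isolates a change at this position. Among the compounds shown here, it gives the direction that the earlier compounds left open: read one bond further out, going from (methoxycarbonyl)methyl to 3-(dimethylamino)propyl lowers the number, and the size of the step is modest. The ester carbonyl and both of its oxygens can therefore leave this position, and a nitrogen can enter it, without a rise in the number in this pair, although no available data bear on why the number moves.

The step changes the chain and its end group together, so the compounds shown do not tell which of the two accounts for it. A carboxylic acid in place of the methyl ester, or a primary amine or morpholine at the end of the same propyl chain, would begin to separate the two.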